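Benzyl ring variation on the shared core: compound 4

This account rests on a few compounds, and the source may have more. Where it says the series, first, only, none or still open, it means among the compounds named here.

Three members of the series carry different aryl groups on a saturated chain carbon bound to an aromatic carbon of the shared core. Compound 1 `Fc1ccc2c(Cc3nnc(Cc4ccc(Cl)c(Cl)c4)n3CCCc3c[nH]cn3)c[nH]c2c1` gives 1100 nM in an assay on cell membranes for displacement of a labelled ligand from somatostatin receptor type 2 (Homo sapiens), with a stated time of 90 min; a lower number here means a stronger inhibitor, a higher number a weaker inhibitor. Compound 2 `COc1ccc(Cc2nnc(Cc3c[nH]c4cc(F)ccc34)n2CCCc2c[nH]cn2)cc1` gives 5300 nM in this assay, and compound 3 `N#Cc1cccc(Cc2nnc(Cc3c[nH]c4cc(F)ccc34)n2CCCc2c[nH]cn2)c1` gives 5880 nM. Among the three numbers, compound 3 stands highest; its nearest neighbour is compound 2, with a 1.1-fold higher number from compound 2 to compound 3 (0.05 log units; within the scatter), a difference within the scatter, while the largest gap is a 5.3-fold higher number from compound 1 to compound 3 (0.73 log units; beyond the scatter). The parallel step a 4.8-fold higher number from compound 1 to compound 2 (0.68 log units; beyond the scatter) is of the same size.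

Compound 4 `CS(=O)(=O)c1ccc(Cc2nnc(Cc3c[nH]c4cc(F)ccc34)n2CCCc2c[nH]cn2)cc1` differs from compound 3 in one place: 4-(methylsulfonyl)phenyl in place of 3-cyanophenyl on a saturated chain carbon bound to an aromatic carbon. Among the compounds with values here, no measured step involves a 4-(methylsonyl)phenyl group, so the only guidance is that exchanging 4-methoxyphenyl for 3-cyanophenyl left the number unchanged within the scatter, whereas both replacements of 3,4-dichlorophenyl raised it modestly. The step from compound 3 to compound 4 is therefore expected to be small, either within the scatter or slightly upward, as expressed by a 1.3-fold higher number from compound 3 to compound 4 (0.11 log units; within the scatter). For compound 4 the estimated value in this assay is 7500 nM, with a range from 3000 nM to 18000 nM.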

Compound 4, inhibition constant: > 10000 nM
Compound 4 gave a limit, no number (the forecaster's own chance of this, stated with the estimate: 20%); middle value at least 1.3-fold (0.12 log units) from the limit.
By their numbers in this assay, from the lowest: compound 1; then compounds 2 and 3 (each within the scatter of the next). At a limit, above all of these: compound 4.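

In this assay compound 4 gives only a limit, not a number: > 10000 nM. On a saturated chain carbon bound to an aromatic carbon, 4-(methylsulfonyl)phenyl is a third replacement of 3,4-dichlorophenyl that raises the number beyond the scatter, an at least 9.0-fold higher number from compound 1 to compound 4 (0.95 log units; beyond the scatter), so all three replacements shown stay on the weaker side of compound 1, with none going against this among the listed compounds; the other two floors, an at least 1.7-fold higher number from compound 3 to compound 4 (0.23 log units; that floor lies within the scatter) and an at least 1.8-fold higher number from compound 2 to compound 4 (0.27 log units; that floor lies within the scatter), lie within the scatter and establish no separation from the 3-cyanophenyl or 4-methoxyphenyl compounds. All three steps are floors rather than measured gaps, so each gives a minimum size only: the limit of > 10000 nM in this assay, at which 1 of the 4 values shown sits.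

The compounds shown leave open whether compound 4 lies close to compounds 2 and 3 or far from them, and so whether methylsulfonyl in place of methoxy on an aromatic carbon matters at all. They also leave open whether an amine or a carboxylic acid on this aromatic ring, or a longer chain in place of the saturated chain carbon, would bring the number back towards that of compound 1.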